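Acyl sulfonamide side-chain variants: permeability notes

The source may hold more compounds than are shown below. What is called first, only, known or untested is meant among the compounds shown, and "the series" means these compounds.

Measured compounds and values:
compound 1 `CC(C)(C)OC(=O)NCCS(=O)(=O)NC(=O)c1ccc(Nc2nc(NC3(c4ccc(Cl)cc4)CC3)nc(OCC(F)(F)F)n2)cc1` — 111 nm/s
compound 2 `O=C(NS(=O)(=O)CCNC(=O)C1CC1)c1ccc(Nc2nc(NC3(c4ccc(Cl)cc4)CC3)nc(OCC(F)(F)F)n2)cc1` — 1 nm/s
compound 3 `CC(C)NC(=O)NCCS(=O)(=O)NC(=O)c1ccc(Nc2nc(NC3(c4ccc(Cl)cc4)CC3)nc(OCC(F)(F)F)n2)cc1` — 45 nm/s

All three share the same core and differ only in the group on the carbonyl carbon of the side chain. In a physicochemical assay for permeability, using PAMPA, at pH 7.4 (a lower number here means that the compound crosses the layer more slowly, a higher number that the compound crosses the layer faster), compound 3 gives 45 nm/s, the second highest of the three numbers; the nearest is a 2.5-fold lower number from compound 1 to compound 3 (0.39 log units; beyond the scatter), the furthest a 45-fold higher number from compound 2 to compound 3 (1.65 log units; beyond the scatter). The remaining step is a 110-fold lower number from compound 1 to compound 2 (2.05 log units; beyond the scatter).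

Compound 4 `O=C(NS(=O)(=O)CCNCc1ccccc1)c1ccc(Nc2nc(NC3(c4ccc(Cl)cc4)CC3)nc(OCC(F)(F)F)n2)cc1` is the next variant. The change is benzyl in place of isopropylcarbamoyl on an amine nitrogen. For the measured compounds named here, none of the measured steps touches this position in the same way: each of them exchanges one group on a carbonyl carbon, whereas here the whole isopropylcarbamoyl unit leaves and a benzyl enters on the amine nitrogen. The measured steps show that this region can move the number strongly in either direction, from modest to large, so a sizeable step is plausible but its direction is not fixed by the data.

The working expectation for compound 4 is a lower number, a 4.5-fold lower number from compound 3 to compound 4 (0.65 log units; beyond the scatter), with compound 4 estimated at 10 nm/s (range 1 nm/s to 60 nm/s).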

Compound 4, apparent permeability: 49 nm/s
Compound 4: middle estimate off by 4.9-fold (0.69 log units), on the low side; low and high end bracket the measured number.
By their numbers in this assay, from the lowest: compound 2; then compounds 3 and 4 (each within the scatter of the next); then compound 1.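

In this assay, the carbonyl on the amine nitrogen of the side chain proves dispensable for a number of this size: benzyl in place of isopropylcarbamoyl gives no change beyond the scatter (a 1.1-fold higher number from compound 3 to compound 4 (0.04 log units; within the scatter)). The same replacement for the other two acyl groups gives (a 49-fold higher number from compound 2 to compound 4 (1.69 log units; beyond the scatter)) and (a 2.3-fold lower number from compound 1 to compound 4 (0.36 log units; beyond the scatter)), so among the four compounds only compound 2 has a very low number, and a carbonyl on this nitrogen does not by itself bring that low number. Nothing available on these compounds explains the pattern.

Going by these compounds, whether the low number belongs to cyclopropylcarbonyl alone stays open, and an acetyl or a cyclohexylcarbonyl on the same nitrogen would bear on that. On these data alone, the free primary amine, and a 2-phenylethyl in place of benzyl, also remain open.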